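Three Solubilities Measured, a Fourth Expected

A few compounds are considered here, and "the series" means these few. Any claim that something is new, unique, unknown or untested is made for them only; others in the source may bear on it.

Compound 1 `CNC(=O)c1cc(C(=O)NC2CCC2)cn(Cc2ccccn2)c1=O`: >= 103 ug/mL
Compound 2 `CNC(=O)c1cc(C(=O)NC2CC2)cn(Cc2ccc3nc[nH]c3c2)c1=O`: >= 163 ug/mL
Compound 3 `CNC(=O)c1cc(C(=O)NCC(C)C)cn(Cc2ccccc2)c1=O`: 43 ug/mL

In a physicochemical assay for solubility (a lower number here means a less soluble compound, a higher number a more soluble compound), compound 2 gives >= 163 ug/mL, which is a limit of the assay and not a number. Compound 1 also reaches a limit, >= 103 ug/mL. Compound 3 alone gives a plain number, 43 ug/mL. Compound 2 therefore stands at the limit of >= 163 ug/mL in this assay, at which 1 of the 3 values shown sits, the higher of the two limits in this set; the other limit is the limit of >= 103 ug/mL in this assay, at which 1 of the 3 values shown sits. Only a limit is known for compound 2, and one further value shown is a limit as well.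

Compound 4 `CNC(=O)c1cc(C(=O)NC2CC2)cn(Cc2cccc(C#N)c2)c1=O` has not yet been measured in this assay. It differs from compound 2 in one place: 3-cyanophenyl in place of 1H-benzimidazol-6-yl on a saturated chain carbon bound to an aromatic nitrogen. Going by the values given here, no step between measured compounds differing in one place is available, so the size of this step rests on expectation only. Compound 3, which gives 43 ug/mL, shows that a compound without the 1H-benzimidazol-6-yl group can give a plain number in this assay. For compound 4 the expected value in this assay is 60 ug/mL, within 25 ug/mL to 150 ug/mL. The step of an at least 2.7-fold lower number from compound 2 to compound 4 (0.43 log units; beyond the scatter) is expected to be a decrease, likely beyond the scatter, though compound 4 may still reach a limit.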

Compound 4, solubility: >= 148 ug/mL
Compound 4: no number, only a limit; the forecaster's own chance of this, stated with the estimate: 25%; at least 2.4-fold (0.39 log units) between middle value and limit.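

In this assay, going by these compounds alone, compound 2 and compound 4 both give a limit of the assay and not a number, so no step between them can be read. The compounds shown leave open whether 3-cyanophenyl in place of 1H-benzimidazol-6-yl changes solubility at all.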